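Swapping an aminohexyl chain for an aminophenyl ring

This account rests on a few compounds, and the source may have more. Where it says the series, first, only, none or still open, it means among the compounds named here.

Measured so far:
compound 1, `COC(=O)c1c(O)c2ccccc2n(C)c1=O`: 8.3%
compound 2, `Cn1c(=O)c(C(=O)NCCCCCCN)c(O)c2ccccc21`: 3.1%
compound 3, `NCCCCCCNC(=O)c1c(O)c2ccccc2n(-c2ccccc2)c1=O`: 11.6%

All three were tested in a functional assay, with a stated time of 20 min, tested at 0.1 mM; on this read-out higher numbers stand for a stronger effect at the one concentration tested and lower numbers for a weaker effect. Going by the values given here, compound 3 carries the only number that is no closer than a number 8.5 percentage points higher from compound 2 to compound 3 (within the scatter), and its gap to compound 1 is also within the scatter, so the three compounds cannot be ranked on these numbers.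

Compound 4, `Nc1ccccc1NC(=O)c1c(O)c2ccccc2n(-c2ccccc2)c1=O`, differs from compound 3 in one place: 2-aminophenyl in place of 6-aminohexyl on an amide-type nitrogen. Among the compounds with values here, no measured step touches the amide-type nitrogen; the one step known, from methyl to phenyl on the aromatic nitrogen, stayed within the scatter. With nothing pointing either way, compound 4 is expected to sit at about a number 0.4 percentage points higher from compound 3 to compound 4 (within the scatter) from compound 3, that is around 12%, most likely between 2% and 25% in this assay.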

Compound 4, a percentage reported as activity, at one concentration (the size of the read-out at that concentration, not a potency): 9.4%
The estimate for compound 4 lay 2.6 percentage points above the measured number; measured number inside the range.
By their numbers in this assay, from the lowest: compounds 2, 1, 4 and 3 (each within the scatter of the next).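

Going by these compounds alone, this is the first change tested on the amide-type nitrogen. In this assay, 2-aminophenyl in place of 6-aminohexyl gives a number 2.2 percentage points lower from compound 3 to compound 4 (within the scatter), so a chain with no ring and a six-membered aromatic ring, each carrying an amine, cannot be told apart here at the one concentration tested. No supporting data bear on this result.

From the compounds shown here alone, it remains open whether any group on this nitrogen can move the number beyond the scatter. A longer chain, or a carboxylic acid in place of the amine, would test this.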